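A few compounds are considered here, and "the series" means these few. Any claim that something is new, unique, unknown or untested is made for them only; others in the source may bear on it.

In a functional assay on HeLa cells (Homo sapiens) for cytotoxicity, read by CCK-8 assay, with a stated time of 24 h (a higher number here means a weaker inhibitor, a lower number a stronger inhibitor), compound 3 `C/C(=C\c1cc(-c2ccc([N+](=O)[O-])cc2)cs1)C(N)=O` gives 2900 nM, the lowest of the two plain numbers here, while compound 2 `C/C(=C\c1cc(-c2ccc(F)cc2)cs1)C(N)=O` gives 20800 nM. Compound 1 `C/C(=C\c1cc(-c2ccc(C)cc2)cs1)C(N)=O` reaches only > 50000 nM, which is a limit of the assay rather than a number. Compound 4 `C/C(=C\c1cc(-c2ccc(C(F)(F)F)cc2)cs1)C(N)=O` has not yet been measured. It differs from compound 3 by trifluoromethyl in place of nitro on an aromatic carbon. Earlier changes at this same place gave an at least 2.4-fold lower number from compound 1 to compound 2 (0.38 log units; beyond the scatter), an at least 17-fold lower number from compound 1 to compound 3 (1.23 log units; beyond the scatter) and a 7.2-fold lower number from compound 2 to compound 3 (0.86 log units; beyond the scatter), so swapping the group on this ring has moved the number widely. Trifluoromethyl has not been tried here; the step is expected to come out as a 2.8-fold higher number from compound 3 to compound 4 (0.44 log units; beyond the scatter), a shift back toward weaker inhibition. Compound 4 is therefore estimated at 8000 nM, with a likely range from 2000 nM to 40000 nM.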

Compound 4, half-maximal inhibitory concentration: > 50000 nM
Compound 4: only a limit was reported; the forecaster's own chance of this, stated with the estimate: 15%; middle value at least 6.2-fold (0.79 log units) from the limit.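

With trifluoromethyl in place of nitro on this aromatic carbon, this assay shows an at least 17-fold higher number from compound 3 to compound 4 (1.23 log units; beyond the scatter) and an at least 2.4-fold higher number from compound 2 to compound 4 (0.38 log units; beyond the scatter), so this position does not accept every replacement for nitro equally. Compound 3 now has the lowest number among the four, and fluoro still gives a plain number where trifluoromethyl does not. Compound 4 stands at a limit, not a number, and its step from compound 1, also a limit, cannot be read: the limit of > 50000 nM in this assay, at which 2 of the 4 values shown sit.

As far as these compounds go, whether an amine, a nitrile or a carboxylic acid at this place would match nitro stays open.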